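The source may hold more compounds than are shown below. What is called first, only, known or untested is meant among the compounds shown, and "the series" means these compounds.

Measured compounds:
- Compound 1, `CN(C)CC[C@H](CSc1ccccc1)Nc1ccc(S(=O)(=O)NC(=O)c2ccc(N3CCN(Cc4ccccc4-c4ccc(Cl)cc4)CC3)cc2)cc1`: 78700 nM
- Compound 2, `CN(C)CC[C@H](CSc1ccccc1)Nc1ccc(S(=O)(=O)NC(=O)c2ccc(N3CCN(Cc4ccccc4-c4ccc(Cl)cc4)CC3)cc2)cc1OC(F)(F)F`: 5080 nM
- Compound 3, `Cc1cc(S(=O)(=O)NC(=O)c2ccc(N3CCN(Cc4ccccc4-c4ccc(Cl)cc4)CC3)cc2)ccc1N[C@H](CCN(C)C)CSc1ccccc1`: 28800 nM

In a functional assay on NCI-H146 cells (Homo sapiens) for cytotoxicity, with a stated time of 48 h, in the presence of a further agent that is not named here (on this read-out higher numbers stand for an effect only at larger amounts of compound and lower numbers for an effect already at smaller amounts), compound 3 gives 28800 nM, the second highest of the three numbers; its nearest neighbour is compound 1, with a 2.7-fold lower number from compound 1 to compound 3 (0.44 log units; beyond the scatter), while compound 2 lies furthest, with a 5.7-fold higher number from compound 2 to compound 3 (0.75 log units; beyond the scatter). Compound 4, `CN(C)CC[C@H](CSc1ccccc1)Nc1ccc(S(=O)(=O)NC(=O)c2ccc(N3CCN(Cc4ccccc4-c4ccc(Cl)cc4)CC3)cc2)cc1C(=O)C(F)(F)F`, is not yet measured. It differs from compound 3 at a single position: (trifluoromethyl)carbonyl in place of methyl on an aromatic carbon.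

Two measured steps speak to this change. Both touch the same aromatic carbon on the shared core: a 15-fold lower number from compound 1 to compound 2 (1.19 log units; beyond the scatter), a large move, and a 2.7-fold lower number from compound 1 to compound 3 (0.44 log units; beyond the scatter), a modest one. A larger fluorine-bearing group at this place has so far gone with the lower number. The incoming group is again a larger, fluorine-bearing group, so the number for compound 4 is expected to fall, with a 4.1-fold lower number from compound 3 to compound 4 (0.61 log units; beyond the scatter), towards the level of compound 2. The estimate for compound 4 in this assay is 7000 nM, with a range from 2000 nM to 25000 nM.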

Compound 4, half-maximal effective concentration: 2010 nM
Compound 4: middle estimate off by 3.5-fold (0.54 log units), on the high side; the measured number falls inside the stated range.
By their numbers in this assay, from the lowest: compound 4; then compound 2; then compound 3; then compound 1.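

In this assay, placing (trifluoromethyl)carbonyl on this aromatic carbon gives a 39-fold lower number from compound 1 to compound 4 (1.59 log units; beyond the scatter) and a 14-fold lower number from compound 3 to compound 4 (1.16 log units; beyond the scatter), so compound 4 has the lowest number of the four compounds. It also goes beyond the trifluoromethoxy group, with a 2.5-fold lower number from compound 2 to compound 4 (0.40 log units; beyond the scatter), which shows that the number at this position can fall further than compound 2 had shown. The low numbers at this place no longer rest on a single fluorine-bearing group, since two different ones now lie below both hydrogen and methyl.

Nothing shown here explains why these groups lower the number. On these data alone, it also remains open whether the carbonyl or the fluorines matter more, which an acetyl group or a plain trifluoromethyl group at this place could help to separate, and how an amine or a carboxylic acid there would compare.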